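Indole substituent swap in a weak hydroxamic acid series

The source may hold more compounds than are shown below. What is called first, only, known or untested is meant among the compounds shown, and "the series" means these compounds.

Measured compounds:
- compound 1, `O=C(COc1ccc(C(=O)NC2CC=C(c3c[nH]c4cccc(F)c34)CC2)cc1)NO`; a functional assay on SW480 cells (Homo sapiens) for antiproliferative activity, with a stated time of 72 h; a higher number here means a weaker inhibitor, a lower number a stronger inhibitor: > 5000 nM
- compound 2, `O=C(COc1ccc(CN2CC=C(c3c[nH]c4cccc(F)c34)CC2)c(F)c1)NO`; this assay: 5560 nM

Compound 1 gives only a limit in this assay, not a number, as recorded in > 5000 nM. Within the two values shown, compound 1 sits at the limit of > 5000 nM in this assay, at which 1 of the 2 values shown sits. Going by the values given here, compound 2 gives 5560 nM in this assay; no step between compound 1 and compound 2 is defined, and the two values are simply both weak.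

The unmeasured compound 3, `Cc1[nH]c2ccccc2c1C1=CCC(NC(=O)c2ccc(OCC(=O)NO)cc2)CC1`, differs from compound 1 by 2-methyl-1H-indol-3-yl in place of 4-fluoro-1H-indol-3-yl on a double-bonded ring carbon. Among the compounds with values here, no step between measured compounds is available in this assay to guide the change. Given the weak readout of compound 1, the expected step from compound 1 to compound 3 is none beyond the scatter, with the result likely to remain a limit. For compound 3 the estimated value is 6000 nM, with an expected range from 2000 nM to 20000 nM. This estimate corresponds to an expected step that the limit leaves unreadable from compound 1 to compound 3.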

Compound 3, half-maximal inhibitory concentration: > 5000 nM
Compound 3: only a limit was reported; the forecaster's own chance of this, stated with the estimate: 55%; the middle value does not contradict the limit.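

In this assay, going by these compounds alone, compound 3 gives > 5000 nM as a limit, and compound 1 also gives only a limit, so no step between compound 1 and compound 3 can be read. The compounds shown leave open whether 2-methyl-1H-indol-3-yl and 4-fluoro-1H-indol-3-yl differ at all on the shared core.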